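Chloro to Ethyl on a Compound at the Assay Limit

This account rests on a few compounds, and the source may have more. Where it says the series, first, only, none or still open, it means among the compounds named here.

Compound 1 `CNC(=O)c1cc(Oc2ccc(NC(=O)c3cc(-c4ccc(Cl)cc4)ncn3)cc2)ccn1` was tested in a functional assay on PC-3 cells (Homo sapiens) for cytotoxicity, read by MTT assay, with a stated time of 72 h; a lower number here means a stronger inhibitor, a higher number a weaker inhibitor. In this assay compound 1 gives > 100000 nM, which is a limit of the assay rather than a number. Two close relatives were measured alongside it. Compound 3 `CNC(=O)c1cc(Oc2ccc(NC(=O)c3cc(-c4ccc(Cl)cc4)ncn3)cc2F)ccn1` carries a fluoro in place of hydrogen on an aromatic carbon; in this assay compound 3 gives > 100000 nM, again a limit. Compound 2 `CNC(=O)c1cc(Oc2ccc(NC(=O)c3cc(-c4ccc(OC)cc4)ncn3)cc2F)ccn1` has methoxy where compound 3 has chloro, and in this assay compound 2 gives 56200 nM. The first of these changes reads a step that the two limits leave unreadable from compound 1 to compound 3; the second reads an at least 1.7-fold higher number from compound 2 to compound 3 (0.25 log units; that floor lies within the scatter). Two of the three values rest at the limit of > 100000 nM in this assay, at which 2 of the 3 values shown sit, so compound 1 stands at the weak end of what the assay can report.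

Compound 4 `CCc1ccc(-c2cc(C(=O)Nc3ccc(Oc4ccnc(C(=O)NC)c4)cc3)ncn2)cc1` differs from compound 1 by ethyl in place of chloro on an aromatic carbon. Among the measured compounds shown here, no measured step exchanges chloro for ethyl, so neither step above bears directly on this change; the only firm anchor is that compound 1 sits at the limit. Compound 4 is therefore expected to remain close to that limit, an estimated step of a number no higher from compound 1 to compound 4 (the limit leaves the size open). The estimated value of compound 4 is 100000 nM, with an expected range from 30000 nM to 300000 nM.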

Compound 4, half-maximal inhibitory concentration: 29300 nM
Estimate against measurement, compound 4: 3.4-fold (0.53 log units) above; measured number outside the range, below it.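

In this assay, the change from 4-chlorophenyl to 4-ethylphenyl reads as an at least 3.4-fold lower number from compound 1 to compound 4 (0.53 log units; beyond the scatter). This is the first change at this position shown to move the number beyond the scatter, since the earlier swap of methoxy for chloro had a floor that stayed within it. The true size of the step remains open, as compound 1 rests on a limit of the assay rather than a number: the limit of > 100000 nM in this assay, at which 2 of the 4 values shown sit.

The compounds shown leave open whether a longer chain such as propyl, or an amine, at this position would lower the number further or return it to the limit. They also leave open whether ethyl would have the same effect on compound 3, which carries the added fluoro.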